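An Amino Group Added to a Cytotoxicity-Silent Core

The compounds below may be only part of what the source reports. "The series", "measured", "known", "first", "only" and "open" are said of these compounds alone.

Compound 1 `ClCc1cccc(Cn2cnc3c(Cl)ncnc32)c1` was tested in a functional assay on SNB-19 cells (Homo sapiens) for cytotoxicity, read by sulforhodamine B assay, with a stated time of 48 h; on this read-out higher numbers stand for lower toxicity in this test and lower numbers for higher toxicity in this test. In this assay compound 1 reaches only the assay limit, reported as > 100000 nM, so no number is known for it. Its companion compound 2 `ClCc1ccccc1Cn1cnc2ncnc(Cl)c21` behaves the same way: in this assay compound 2 also gives only the limit of > 100000 nM. Compound 1 therefore stands nowhere in particular among the numbers shown, since there are no numbers, only the shared limit described by the limit of > 100000 nM in this assay, at which 2 of the 2 values shown sit. Among the compounds with values here, compound 1 and compound 2 differ in where the substituent sits on the benzyl ring, and no step between them has been computed, so all that can be said is that both sit at the limit.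

Compound 3 `Nc1nc(Cl)c2ncn(Cc3cccc(CCl)c3)c2n1` has not been measured in this assay. It differs from compound 1 by amino in place of hydrogen on an aromatic carbon. Within the data shown here, with no measured step to lean on, and both known values sitting at the limit, compound 3 is expected to remain at or near that limit, with a step from compound 1 to compound 3 of a number no higher from compound 1 to compound 3 (the limit leaves the size open) that is not expected to exceed the scatter. Compound 3 is estimated at 100000 nM in this assay, within a range from 40000 nM to 300000 nM.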

Compound 3, concentration lethal to 50% of the cells: 46800 nM
For compound 3 the middle estimate is 2.1-fold (0.33 log units) above the measured one, within the range that was stated.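

Amino in place of hydrogen, on the aromatic carbon between two ring nitrogen atoms, is the first change shown that moves the read-out in this assay away from the limit, giving an at least 2.1-fold lower number from compound 1 to compound 3 (0.32 log units; beyond the scatter) and so higher toxicity in this test. On these data alone, the starting point of this step, compound 1, is a limit and not a number, so the full size of the step stays open. Compound 3 is the only compound shown that carries a number rather than a limit: the limit of > 100000 nM in this assay, at which 2 of the 3 values shown sit.

The compounds shown leave open whether the same shift would follow from another group on this carbon, such as a hydroxyl, a methoxy or a methylamino, or whether it belongs to the amino group alone. They also leave open whether amino at this place would move compound 2, with its different substitution on the benzyl ring, away from the limit as well, and what would happen if an amine took the place of the chloro group on the same ring.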